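The source may report more compounds than this note shows. Statements on the series, on what has been measured and on what is new or still open speak of the compounds shown alone.

In a functional assay on HL-60 cells (Homo sapiens) for cytotoxicity, read by MTT assay, with a stated time of 48 h (a higher number here means a weaker inhibitor, a lower number a stronger inhibitor), compound 2 `C=C1C(=O)OC(C)CC1c1ccc(Br)cc1` gives 4770 nM. For the measured compounds named here, its only measured neighbour is compound 1 `C=C1C(=O)OC(C)CC1c1ccc([N+](=O)[O-])cc1`, which in this assay gives 6120 nM; the step of a 1.3-fold lower number from compound 1 to compound 2 (0.11 log units; within the scatter) leaves the two numbers within the scatter of each other, so compound 2 stands level with compound 1 on what has been measured. Compound 3 `C=C1C(=O)OC(C)CC1c1ccc(OC)cc1` is compound 2 with methoxy in place of bromo on an aromatic carbon. Going by the values given here, the one measured step that bears on this change is the earlier exchange on an aromatic carbon, a 1.3-fold lower number from compound 1 to compound 2 (0.11 log units; within the scatter), which did not move the number beyond the scatter; it swapped nitro for bromo rather than bromo for methoxy, so it is only a loose guide. With nothing else to draw on, no step beyond the scatter is expected in this assay. Compound 3 is therefore estimated at 5500 nM, with a range from 2500 nM to 12000 nM. The expected step is a 1.2-fold higher number from compound 2 to compound 3 (0.06 log units; within the scatter).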

Compound 3, half-maximal inhibitory concentration: 5950 nM
For compound 3 the middle estimate is 1.1-fold (0.03 log units) below the measured one; measured number inside the range.
By their numbers in this assay, from the lowest: compounds 2, 3 and 1 (each within the scatter of the next).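

With methoxy in place of bromo, this assay gives a 1.2-fold higher number from compound 2 to compound 3 (0.10 log units; within the scatter) and, with methoxy in place of nitro, a 1.0-fold lower number from compound 1 to compound 3 (0.01 log units; within the scatter) on the same aromatic carbon. Nitro, bromo and methoxy thus make three groups at this place that stand level with one another, and methoxy adds a hydrogen-bond acceptor that bromo lacks without the number leaving the scatter. No measurement shown here explains this lack of separation.

The compounds shown leave open whether an amine, a carboxylic acid or a longer alkoxy chain at this place would move the number beyond the scatter. They also leave open whether a change elsewhere on the shared core would do so, as all three compounds differ only at this one aromatic carbon.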